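The source may report more compounds than this note shows. Statements on the series, on what has been measured and on what is new or still open speak of the compounds shown alone.

Values in an in vitro ADME assay on microsomes (Homo sapiens) for metabolic stability (a higher number here means that the compound lasts longer, a lower number that the compound disappears faster), so far
compound 1 `CCc1nc(-c2ccc(Cl)cc2Cl)c(CC)nc1CC(CC)CC` gives 0.217 h
compound 2 `CCc1nc(-c2ccc(OC)cc2C(F)(F)F)c(CC)nc1NC(CC)CC` gives 0.2 h
compound 3 `CCc1nc(-c2ccc(Cl)cc2Cl)c(OC)nc1NC(CC)CC` gives 0.7 h

Compound 1 at 0.217 h and compound 2 at 0.2 h lie within the scatter of each other, while compound 3 at 0.7 h is higher than both and beyond the scatter. Compound 1 therefore stands in the lower part of this small range.

The next structure is compound 4 `CCCN(CC1CC1)c1nc(CC)c(-c2ccc(Cl)cc2Cl)nc1CC` and its change from compound 1 is (cyclopropylmethyl)(propyl)amino in place of 2-ethylbutyl on an aromatic carbon with the new group para to a 2,4-dichlorophenyl group. Within the data shown here, no measured pair isolates this change. Compound 2 and compound 3 also attach their chain through nitrogen, but they differ from compound 1 elsewhere too and their values show no single direction for that link.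

The expectation therefore rests on compound 1 at 0.217 h as the closest measured structure. The expected change a 1.1-fold lower number from compound 1 to compound 4 (0.04 log units; within the scatter) is no step beyond the scatter. For compound 4 the estimated half-life is 0.2 h with an expected range from 0.08 h to 0.5 h until it is measured.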

Compound 4, half-life: 0.2 h
Compound 4: the middle estimate sits on the measured number at the digits printed, and the stated range covers the measured number.
By their numbers in this assay, from the lowest: compounds 2, 4 and 1 (each within the scatter of the next); then compound 3.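

In this assay, among these compounds, the replacement of 2-ethylbutyl by (cyclopropylmethyl)(propyl)amino on the aromatic carbon para to the 2,4-dichlorophenyl group gives a 1.1-fold lower number from compound 1 to compound 4 (0.04 log units; within the scatter) and is the first comparison that differs in one place only. At this position, with both ethyl groups and the 2,4-dichlorophenyl group unchanged, half-life does not separate the carbon-linked 2-ethylbutyl chain from the nitrogen-linked group, even though the latter adds a three-membered ring and a hydrogen-bond acceptor. No measurement at hand offers an explanation for this result.

As far as these compounds go, whether half-life stays the same with other groups at this position remains open, for example with a morpholine or a carboxylic acid. Also open, from the compounds shown here alone, is whether this result carries over to a core with a different group in place of either ethyl group.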